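Trading Two Methoxy Groups for Two Fluorines on Compound 1

A few compounds are considered here, and "the series" means these few. Any claim that something is new, unique, unknown or untested is made for them only; others in the source may bear on it.

Of the compounds shown here, three have so far been measured in a functional assay on BGC-823 cells (Homo sapiens) for antiproliferative activity, read by MTT assay, tested at 1 uM; a higher number here means a stronger effect of the compound at the concentration tested, a lower number a weaker effect. Compound 1 `COc1ccc(C2OC(c3cc(OC)c(OC)c(OC)c3)=NN2C(C)=O)c(OC)c1` gives 6.3% in this assay, the highest of the three numbers. Compound 2 `COc1cccc(/C=N/NC(=O)c2cc(OC)c(OC)c(OC)c2)c1OC` gives -0.1%, which sits within the scatter of compound 1, so the two cannot be ordered. Compound 3 `COc1cc(C(=O)N/N=C/c2cc(Cl)cc(Cl)c2)cc(OC)c1OC` gives -7.5%, a number beyond the scatter below compound 1. Among the measured compounds shown here, no step between two measured compounds that differ in a single place is available. Compound 4 `COc1cc(C2=NN(C(C)=O)C(c3ccc(F)c(F)c3)O2)cc(OC)c1OC` differs from compound 1 in one place: 3,4-difluorophenyl in place of 2,4-dimethoxyphenyl on a saturated ring carbon. For the measured compounds named here, with every value so far close to zero and no comparable step to draw on, a number 2.3 percentage points lower from compound 1 to compound 4 (within the scatter) is expected to stay within the scatter. Compound 4 is therefore estimated at 4%, with a range from -10% to 18%.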

Compound 4, a percentage reported as inhibition, at one concentration (the size of the read-out at that concentration, not a potency): 18.3%
Beside the measured number, compound 4's estimate is 14.3 percentage points below it; the whole stated range lies below it.
By their numbers in this assay, from the lowest: compounds 3, 2 and 1 (each within the scatter of the next, the first and the last beyond it); then compound 4.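

Among the compounds shown here, the step of a number 12 percentage points higher from compound 1 to compound 4 (beyond the scatter) in this assay is the first comparison of compounds that differ in one place, and it shows that the group on this saturated ring carbon can move the read-out beyond the scatter. Because the change replaces 2,4-dimethoxyphenyl with 3,4-difluorophenyl as a whole, the step cannot be assigned to losing the methoxy groups or to gaining the fluorines. Nothing available explains the rise.

On these data alone, it remains open whether a phenyl carrying a single fluorine, a chlorine or an amine at this carbon would give a similar step.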